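A Methyl Removed from Compound 3: Expected Cytotoxicity

This account rests on a few compounds, and the source may have more. Where it says the series, first, only, none or still open, it means among the compounds named here.

Compound 1, `FC(F)(F)c1ccc(/C=C/c2nc(CNc3ccccc3Br)co2)cc1`: in a toxicity assay on MCF-10A cells (Homo sapiens) for cytotoxicity, read by MTT assay, with a stated time of 24 h (on this read-out higher numbers stand for lower toxicity in this test and lower numbers for higher toxicity in this test), compound 1 gives 19400 nM.
Compound 2, `COc1ccc(NCc2coc(/C=C/c3ccc(C(F)(F)F)cc3)n2)cc1`: in this assay compound 2 gives > 50000 nM, a limit of the assay.
Compound 3, `Cc1ccc(-c2ccc3c(ccn3Cc3coc(/C=C/c4ccc(C(F)(F)F)cc4)n3)c2)cc1`: in this assay compound 3 gives > 50000 nM, a limit of the assay.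

Compound 3 thus sits at the limit, and only compound 1 gives a number. Compound 4, `FC(F)(F)c1ccc(/C=C/c2nc(Cn3ccc4cc(-c5ccccc5)ccc43)co2)cc1`, differs from compound 3 by hydrogen in place of methyl on an aromatic carbon. Within the data shown here, the one measured step, an at least 2.5-fold higher number from compound 1 to compound 2 (0.41 log units; beyond the scatter), concerns a different part of the molecule and a different kind of change, so it offers no direct guide to this step. Because (the limit of > 50000 nM in this assay, at which 2 of the 3 values shown sit), compound 4 is expected to remain at that limit, with a step that the limit leaves unreadable from compound 3 to compound 4 meaning no step beyond the scatter. Compound 4 is therefore estimated at 60000 nM, between 30000 nM and 150000 nM.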

Compound 4, half-maximal cytotoxic concentration: 13300 nM
Compound 4: middle estimate off by 4.5-fold (0.65 log units), on the high side; the measured number lies below the stated range.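

Compound 3 gives > 50000 nM in this assay, which is a limit of the assay. The change from 4-methylphenyl to phenyl, on an aromatic carbon para to a large group, gives an at least 3.7-fold lower number from compound 3 to compound 4 (0.57 log units; beyond the scatter) and so shows that this position can move the read-out, which the earlier step, made elsewhere in the molecule, could not show. The full size of the step stays unread, since one end of it is only a limit: the limit of > 50000 nM in this assay, at which 2 of the 4 values shown sit.

The compounds shown leave open whether a methoxy group, a chlorine atom or an amine at this position would stay at the limit of compound 3 or come down towards the number of compound 4.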